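A few compounds are considered here, and "the series" means these few. Any claim that something is new, unique, unknown or untested is made for them only; others in the source may bear on it.

Measured in a functional assay on BJAB cells (Homo sapiens) for antiproliferative activity, with a stated time of 4 days; a lower number here means that less compound is needed, a higher number that more compound is needed for the effect:
- compound 1, `Cc1nn(-c2nc(-c3ccc(Cl)c(Cl)c3)c(SC(C)C)s2)c(C(=O)O)c1-c1cccc(Cl)c1C`: 5100 nM
- compound 2, `CC(=O)Nc1ccc(-c2c(C)nn(-c3nc(-c4ccc(Cl)c(Cl)c4)c(SC(C)C)s3)c2C(=O)O)cc1`: 139000 nM
- compound 3, `Cc1nn(-c2nc(-c3ccc(Cl)c(Cl)c3)c(SC(C)C)s2)c(C(=O)O)c1-c1ccccc1Cl`: 13100 nM

Compound 2 stands at the highest number of the three, so it needs the most compound for the effect. The nearest of the other two is reached by an 11-fold lower number from compound 2 to compound 3 (1.03 log units; beyond the scatter), the furthest by a 27-fold higher number from compound 1 to compound 2 (1.44 log units; beyond the scatter); both gaps lie beyond the scatter.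

Compound 4, `Cc1nn(-c2nc(-c3ccc(Cl)c(Cl)c3)c(SC(C)C)s2)c(C(=O)O)c1-c1ccccc1[N+](=O)[O-]`, has not yet been measured. It differs from compound 2 in one place: 2-nitrophenyl in place of 4-acetamidophenyl on an aromatic carbon. The two steps away from compound 2 both bear on this change, since each also removes the 4-acetamidophenyl, and both were large. The entering 2-nitrophenyl resembles the 2-chlorophenyl of compound 3 more than it resembles the 4-acetamidophenyl that leaves. The closest guide is an 11-fold lower number from compound 2 to compound 3 (1.03 log units; beyond the scatter). A large step to a lower number is therefore expected in this assay, roughly a 9.3-fold lower number from compound 2 to compound 4 (0.97 log units; beyond the scatter). For the measured compounds named here, no measured compound carries a nitro group, so the estimate is less certain than the steps it rests on. For compound 4 the expected value is 15000 nM, with a range from 4000 nM to 60000 nM.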

Compound 4, half-maximal effective concentration: 4700 nM
For compound 4 the middle estimate is 3.2-fold (0.50 log units) above the measured one, within the range that was stated.
By their numbers in this assay, from the lowest: compounds 4 and 1 (each within the scatter of the next); then compound 3; then compound 2.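

In this assay, replacing the 4-acetamidophenyl with 2-nitrophenyl also gives a large drop in the number (a 30-fold lower number from compound 2 to compound 4 (1.47 log units; beyond the scatter)), so at this ring position the large drop seen with 2-chlorophenyl is not confined to a chloro group. The group on that phenyl ring still matters when nitro takes the place of chloro, and this change gives a modest step that lies beyond the scatter (a 2.8-fold lower number from compound 3 to compound 4 (0.45 log units; beyond the scatter)). The 2-nitrophenyl and 3-chloro-2-methylphenyl groups cannot be told apart here, as their difference lies within the scatter (a 1.1-fold lower number from compound 1 to compound 4 (0.04 log units; within the scatter)).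

The data shown offer no explanation for any of these differences. As far as these compounds go, whether an amine or a carboxylic acid in the place of the nitro would keep the number as low remains open.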